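Trimming a tert-butyl to isopropyl on the ester aryl

A few compounds are considered here, and "the series" means these few. Any claim that something is new, unique, unknown or untested is made for them only; others in the source may bear on it.

Of the compounds shown here, three sharing one core have been tested in a functional assay on the whole organism (strain Swiss albino) for inhibition, with Mus musculus as the target, read by paw edema, with stated times of 30 min and 90 min, at a dose of 100 mg/kg by the subcutaneous route; on this read-out higher numbers stand for more inhibition at the one dose given (going by the name of the read-out) and lower numbers for less inhibition. Compound 1, `Cc1ccc(-c2cc(C(=O)NNc3ccc4ccccc4n3)n(Cc3ccccc3)n2)cc1`, carries a hydrazide link to a bicyclic aromatic group; in this assay compound 1 gives 23%. Compound 2, `Cc1ccc(-c2cc(C(=O)Oc3ccc(-n4ccnc4)cc3)n(Cc3ccccc3)n2)cc1`, is an ester whose phenyl ring bears an imidazolyl group; compound 2 gives 6.6%. Compound 3, `Cc1ccc(-c2cc(C(=O)Oc3ccc(C(C)(C)C)cc3)nn2Cc2ccccc2)cc1`, is an ester whose phenyl ring bears a tert-butyl group; compound 3 gives 26%.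

Compound 3 shows the largest of the three numbers. Its nearest neighbour is compound 1, whose value lies within the usual scatter of the method, so no real order between compounds 1 and 3 can be read. Compound 2 sits beyond the scatter, clearly lower than compound 3.

Compound 4, `Cc1ccc(-c2cc(C(=O)Oc3ccc(C(C)C)cc3)nn2Cc2ccccc2)cc1`, has not yet been measured. It differs from compound 3 in one place only: hydrogen in place of methyl on a saturated chain carbon bound to an aromatic carbon and two saturated chain carbons. Such a small trimming of a saturated chain, with no change in rings, hydrogen-bond donors or acceptors, gives little reason to expect a large shift in this assay. The step from compound 3 to compound 4 is expected to be a number 4 percentage points lower from compound 3 to compound 4 (within the scatter), that is, none beyond the scatter. Compound 4 is therefore estimated at 22%, within a range from 8% to 38%.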

Compound 4, a percentage reported as inhibition, in the whole organism at one dose (the size of the read-out at that dose, not a potency): 27.4%
The estimate for compound 4 lay 5.4 percentage points below the measured number; low and high end bracket the measured number.
By their numbers in this assay, from the lowest: compound 2; then compounds 1, 3 and 4 (each within the scatter of the next).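

In this assay, trimming the tert-butyl to isopropyl on the ester's phenyl ring gives a number 1.4 percentage points higher from compound 3 to compound 4 (within the scatter). Going by these compounds alone, this is the first pair here that differs in one place only, so it gives the first direct comparison at this position, and the two compounds cannot be told apart in this read-out. Losing one methyl from the saturated chain carbon bound to the aromatic carbon therefore leaves no detectable mark on inhibition at this dose, although nothing available bears on why the result came out this way.

As far as these compounds go, a single small trimming says little about larger changes at the same place, so it remains open whether an ethyl group, a longer chain, an amine or a carboxylic acid on the phenyl ring would also leave the number in this assay within the scatter. From the compounds shown here alone, with both compounds read at one dose, it also remains open whether the two would stay level at other doses.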